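Series notes: the phenyl to 4-bromophenyl step

The source may report more compounds than this note shows. Statements on the series, on what has been measured and on what is new or still open speak of the compounds shown alone.

In a functional assay on PC-3 cells (Homo sapiens) for cytotoxicity, read by MTT assay, with a stated time of 72 h (a lower number here means a stronger inhibitor, a higher number a weaker inhibitor), compound 1 `COc1ccc(Nc2nc3ccccc3nc2S(=O)(=O)c2ccccc2)cc1` gives 1510 nM. Compound 3 `Nc1cccc(Nc2nc3ccccc3nc2S(=O)(=O)c2ccccc2)c1` gives 2150 nM, and the series shows a 1.4-fold higher number from compound 1 to compound 3 (0.15 log units; within the scatter), so these two values cannot be told apart. Compound 2 `COc1cc(Nc2nc3ccccc3nc2S(=O)(=O)c2ccccc2)cc(OC)c1` gives 140 nM, clearly under both, with an 11-fold lower number from compound 1 to compound 2 (1.03 log units; beyond the scatter) and a 15-fold higher number from compound 2 to compound 3 (1.19 log units; beyond the scatter).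

Compound 4 `COc1ccc(Nc2nc3ccccc3nc2S(=O)(=O)c2ccc(Br)cc2)cc1` keeps the 4-methoxyphenyl on nitrogen of compound 1 and alters the other phenyl: bromo in place of hydrogen on an aromatic carbon. In words, this is bromo in place of hydrogen on an aromatic carbon, para to a large group, or phenyl to 4-bromophenyl.

All three measured steps change the group on nitrogen, and none touches this phenyl, so none carries over directly. Going by the values given here, they show only that one change can be large or can stay within the scatter. The data give no direction for bromo here, so the working expectation in this assay is no step beyond the scatter, held with a wide margin. The expected step is a 1.2-fold lower number from compound 1 to compound 4 (0.07 log units; within the scatter). The estimate for compound 4 is 1300 nM, with an expected range of 400 nM to 4000 nM.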

Compound 4, half-maximal inhibitory concentration: 1110 nM
Estimate against measurement, compound 4: 1.2-fold (0.07 log units) above; the range from low to high includes it.
By their numbers in this assay, from the lowest: compound 2; then compounds 4, 1 and 3 (each within the scatter of the next).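

In this assay, bromo in place of hydrogen on an aromatic carbon, para to a large group, gives a 1.4-fold lower number from compound 1 to compound 4 (0.13 log units; within the scatter), so the two values cannot be told apart. Going by these compounds alone, this is the first reading on the phenyl that the earlier steps left untouched, and this single change stays within the scatter, whereas the step on the group on nitrogen reaches an 11-fold lower number from compound 1 to compound 2 (1.03 log units; beyond the scatter); one substituent at one place, however, does not describe the whole phenyl. No measured evidence here bears on why the bromo leaves the value within the scatter.

On these data alone, whether the bromo would behave the same way alongside the 3,5-dimethoxyphenyl on nitrogen of compound 2, which gives 140 nM, remains open, since a step measured on the background of compound 1 need not carry over to another background. Also open, as far as these compounds go, is whether an amine or a carboxylic acid at the same place on this phenyl would likewise stay within the scatter or would produce a step as large as those seen on nitrogen.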